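The source may report more compounds than this note shows. Statements on the series, on what has been measured and on what is new or still open speak of the compounds shown alone.

Compound 1, with the structure `CCC(C)n1ncn(-c2ccc(N3CCN(c4ccc(OC[C@@H]5CO[C@@](Cn6cncn6)(c6ccc(Cl)cc6Cl)O5)nc4)CC3)cc2)c1=O`, is the starting point of this set. In a physicochemical assay for solubility, read by HPLC, measured as thermodynamic solubility (a higher number here means a more soluble compound, a lower number a less soluble compound), compound 1 gives 0.116 ug/mL. Compound 2, drawn as `CCC(C)n1ncn(-c2ccc(N3CCN(c4ccc(OC[C@@H]5CO[C@@](Cn6cncn6)(c6ccc(Cl)cc6Cl)O5)nc4)CC3)c(F)c2)c1=O`, carries the change fluoro in place of hydrogen on an aromatic carbon on the same core, and in this assay compound 2 gives 0.255 ug/mL. The step this change made is a 2.2-fold higher number from compound 1 to compound 2 (0.34 log units; beyond the scatter).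

Compound 3, with the structure `CCC(C)n1ncn(-c2ccc(N3CCN(c4ccc(OC[C@@H]5CO[C@@](Cn6ccnc6)(c6ccc(Cl)cc6Cl)O5)cn4)CC3)cc2)c1=O`, stands on a different core; the difference between the two cores is not broken down here. In this assay, going by the values given here, compound 3 gives 2.94 ug/mL, the highest of the three numbers measured so far and beyond the scatter from both compound 1 and compound 2.

Compound 4, drawn as `CCC(C)n1ncn(-c2ccc(N3CCN(c4ccc(OC[C@@H]5CO[C@@](Cn6ccnc6)(c6ccc(Cl)cc6Cl)O5)cn4)CC3)c(F)c2)c1=O`, has not yet been measured in this assay. It differs from compound 3 by fluoro in place of hydrogen on an aromatic carbon, the same change that separates compound 2 from compound 1, placed on an aromatic carbon of a six-membered aromatic ring of carbon only, ortho to a large group and meta to a large group, in both cases. Among the compounds with values here, the expected step from compound 3 to compound 4 is a 2.0-fold higher number from compound 3 to compound 4 (0.31 log units; beyond the scatter), which rests on the measured step of a 2.2-fold higher number from compound 1 to compound 2 (0.34 log units; beyond the scatter), the only example of this change in the set; whether the step transfers from one core to the other is not known from these three compounds. On that basis compound 4 is estimated to give 6 ug/mL in this assay, with the range 2.5 ug/mL to 15 ug/mL considered likely.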

Compound 4, solubility: 125 ug/mL
Compound 4: middle estimate off by 21-fold (1.32 log units), on the low side, and the stated range ends below it.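

In this assay, fluoro in place of hydrogen on an aromatic carbon gave a 43-fold higher number from compound 3 to compound 4 (1.63 log units; beyond the scatter) on the core of compound 3, while the same change in the same kind of place gave a 2.2-fold higher number from compound 1 to compound 2 (0.34 log units; beyond the scatter) on the core of compound 1, so across these two pairs the direction of the step carried over from one core to the other, but its size, modest on one core and large on the other, did not. Going by these compounds alone, with only two pairs, the step seen on one core proved a poor guide to the size of the step on the other, and this does not establish a rule for any further core, nor that the direction would hold there. Nothing given here bears on why the same change gave steps of such different size on the two cores.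

The difference between the two cores is not broken down, so the compounds shown leave open which part of it goes with the large step, and whether the change would again give a higher number on a third core. They also leave open what a methoxy group or a nitrile would give in place of the fluoro on that same aromatic carbon, on either core, and how those steps would compare with the two fluoro steps.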